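A few compounds are considered here, and "the series" means these few. Any claim that something is new, unique, unknown or untested is made for them only; others in the source may bear on it.

Measured in a functional assay on SK-HEP1 cells (Homo sapiens) for cytotoxicity, read by sulforhodamine B assay, with a stated time of 72 h; a higher number here means a weaker inhibitor, a lower number a stronger inhibitor:

- Compound 1 `OCC1=C(F)[C@@H](n2cnc3c(NC4CC4)ncnc32)[C@H](O)[C@@H]1O`: > 100000 nM (a limit)
- Compound 2 `Nc1nc(O)c2ncn([C@@H]3C(F)=C(CO)[C@@H](O)[C@H]3O)c2n1`: > 100000 nM (a limit)
- Compound 3 `Nc1nc(N)c2ncn([C@@H]3C(F)=C(CO)[C@@H](O)[C@H]3O)c2n1`: > 100000 nM (a limit)

None of these entries is a true number, since each one is a limit of the assay. Compound 3 therefore has no exact position, only the same reading as the two others. Within the data shown here, the whole series so far comes down to the limit of > 100000 nM in this assay, at which 3 of the 3 values shown sit.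

The next compound is compound 4 `Nc1nc(NC2CC2)c2ncn([C@@H]3C(F)=C(CO)[C@@H](O)[C@H]3O)c2n1`. It is made from compound 3 by one change: cyclopropyl in place of hydrogen on a nitrogen on an aromatic ring. Put simply, amino becomes cyclopropylamino, with cyclopropyl in place of hydrogen on a nitrogen on an aromatic ring.

The measured data offer little guidance on the size of this change. Among the measured compounds shown here, the only measured step is a step that the two limits leave unreadable from compound 2 to compound 3, so it gives no size to carry over. Compound 1, which also carries a cyclopropyl on a nitrogen, still reads > 100000 nM, again a limit. No clear gain in this assay can therefore be predicted, and a reading at the same limit seems the likeliest result.

The expected change is a number no higher from compound 3 to compound 4 (the limit leaves the size open), and no shift beyond the scatter is anticipated. The estimate for compound 4 is 100000 nM, with an expected range from 30000 nM to 200000 nM.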

Compound 4, half-maximal inhibitory concentration: > 100000 nM
Compound 4: no number, only a limit; the forecaster's own chance of this, stated with the estimate: 80%; the middle value sits exactly at the limit.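

No step to compound 4 from compound 1, compound 2 or compound 3 can be read, because every reading in this assay is a limit and not a number: the limit of > 100000 nM in this assay, at which 4 of the 4 values shown sit.

The compounds shown leave open whether any of these group changes alters cytotoxicity at all, and which group, if any, would bring a reading that is a true number.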